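The compounds below may be only part of what the source reports. "The series", "measured", "known", "first", "only" and "open" are said of these compounds alone.

Of the compounds shown here, three with one shared core have been measured. Compound 1 `COc1ccc(S(=O)(=O)c2cnc3ccc(C)cc3c2N2CCC(C)CC2)cc1Cl` gives 93% in an assay on isolated protein for displacement of a labelled ligand from metabotropic glutamate receptor 5 (Homo sapiens), with a stated time of 60 min, tested at 1 uM; a lower number here means less inhibition, a higher number more inhibition at the concentration tested (going by the name of the read-out). Compound 2 `Cc1ccc2ncc(S(=O)(=O)c3ccc(F)cc3)c(N3CCC(C)CC3)c2c1` gives 90% in this assay. Compound 3 `COc1ccc2ncc(S(=O)(=O)c3ccc(Cl)c(Cl)c3)c(N3CCC(C)CC3)c2c1` gives 87% in this assay, the lowest of the three numbers shown, though its gaps to compound 2 and to compound 1 both lie within the scatter. Compound 4 `Cc1ccc2ncc(S(=O)(=O)c3ccc(Cl)c(Cl)c3)c(N3CCC(C)CC3)c2c1` differs from compound 3 in one place: methyl in place of methoxy on an aromatic carbon. Among the measured compounds shown here, no measured step touches that place; the only measured step, a number 3 percentage points lower from compound 1 to compound 2 (within the scatter), concerns the group on a sulfonyl sulfur and stays within the scatter. The step of a number 2 percentage points higher from compound 3 to compound 4 (within the scatter) is therefore expected to stay within the scatter as well. Compound 4 is estimated to give 89%, with a range from 79% to 97%.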

Compound 4, a percentage reported as inhibition, at one concentration (the size of the read-out at that concentration, not a potency): 82%
Estimate against measurement, compound 4: 7 percentage points above; measured number inside the range.
By their numbers in this assay, from the lowest: compounds 4, 3, 2 and 1 (each within the scatter of the next, the first and the last beyond it).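

In this assay, the first step measured at this aromatic carbon of the shared core, a number 5 percentage points lower from compound 3 to compound 4 (within the scatter), shows that methyl can replace methoxy here without a change beyond the scatter. Changing the group on the sulfonyl sulfur gives a number 8 percentage points lower from compound 2 to compound 4 (within the scatter), also inside the scatter. Only chloro in place of methoxy on the sulfonyl-bound aromatic ring, a number 11 percentage points lower from compound 1 to compound 4 (beyond the scatter), goes beyond it, and modestly.

Nothing available gives a reason for these steps. Going by these compounds, whether an amine or ethoxy at the core position would hold the inhibition remains open.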